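Bromo for cyano on a triazene with long half-life

The compounds below may be only part of what the source reports. "The series", "measured", "known", "first", "only" and "open" are said of these compounds alone.

Compound 2, `CN(/N=N/c1ccc(C#N)cc1)C(=O)NCCSc1ccc(O)cc1`, stands at the top end of what is known. In a physicochemical assay for pharmacokinetics, read by HPLC, in phosphate buffer, at pH 7.4 (a lower number here means that the compound disappears faster, a higher number that the compound lasts longer), compound 2 gives > 240 h, which is a limit of the assay rather than a number. Compound 1, `CCOC(=O)c1ccc(/N=N/N(C)C(=O)NCCSc2ccc(O)cc2)cc1`, differs from it only in carrying an ethoxycarbonyl group where compound 2 carries cyano; in this assay compound 1 gives > 240 h, again a limit. Going by the values given here, the one measured step is therefore a step that the two limits leave unreadable from compound 1 to compound 2, and the only firm observation is the limit of > 240 h in this assay, at which 2 of the 2 values shown sit. Compound 3, `CN(/N=N/c1ccc(Br)cc1)C(=O)NCCSc1ccc(O)cc1`, is reached by bromo in place of cyano on an aromatic carbon. Among the compounds with values here, no measured step shows a substituent on that ring carbon pulling the half-life back into readable range, so compound 3 is expected to stay near the limit, with a step that the limit leaves unreadable from compound 2 to compound 3 as the estimated change. The estimate for compound 3 is 300 h, within a range from 120 h to 800 h.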

Compound 3, half-life: > 240 h
Compound 3: only a limit was reported (the forecaster's own chance of this, stated with the estimate: 80%); the middle value lies beyond the limit too.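

Going by these compounds alone, no step among compound 1, compound 2 and compound 3 can be read, and the only firm observation is a limit rather than a number: the limit of > 240 h in this assay, at which 3 of the 3 values shown sit. The compounds shown leave open how long each actually lasts, and whether ethoxycarbonyl, cyano or bromo on that aromatic carbon changes the half-life at all.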